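This account rests on a few compounds, and the source may have more. Where it says the series, first, only, none or still open, it means among the compounds named here.

Working notes on the series. Among the compounds with values here, compound 2 `CCCc1cc(N)c2cc(NC(=O)/C=C/c3ccc(SC)cc3)ccc2n1` carries a methylsulfanyl group on the aromatic ring at the end of the cinnamamide chain and in an assay on isolated protein for displacement of a labelled ligand from melanin-concentrating hormone receptor 1 (Homo sapiens) (a lower number here means a stronger inhibitor, a higher number a weaker inhibitor), compound 2 gives 9 nM, the higher of the two numbers measured so far. Within the data shown here, its only neighbour, compound 1 `CCCc1cc(N)c2cc(NC(=O)/C=C/c3ccc(CC)cc3)ccc2n1`, differs from it by a single group, and in this assay compound 1 gives 1.4 nM; the step of a 6.4-fold higher number from compound 1 to compound 2 (0.81 log units; beyond the scatter) puts methylsulfanyl in place of ethyl at the same ring position. Compound 3 `CCCc1cc(N)c2cc(NC(=O)/C=C/c3ccc(Cl)c(Cl)c3)ccc2n1` is not yet measured. It differs from compound 2 by 3,4-dichlorophenyl in place of 4-(methylsulfanyl)phenyl on a double-bonded chain carbon bound to a double-bonded chain carbon. Among the measured compounds shown here, no measured step exchanges the whole aryl group or introduces chlorine, so the one step on record, from ethyl to methylsulfanyl, does not bear directly on this change; it only shows that the numbers at this end of the molecule move beyond the scatter between small substituents. For the measured compounds named here, with no closer precedent the expectation for compound 3 is a number of roughly the same order as compound 2, with wide uncertainty, and the step of a 1.5-fold lower number from compound 2 to compound 3 (0.18 log units; within the scatter) is estimated to stay modest in either direction. Compound 3 is therefore expected to give about 6 nM in this assay, with a range from 1.5 nM to 30 nM.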

Compound 3, half-maximal inhibitory concentration: 60 nM
For compound 3 the middle estimate is 10-fold (1.00 log units) below the measured one; the whole stated range lies below it.
By their numbers in this assay, from the lowest: compound 1; then compound 2; then compound 3.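

The whole aryl group on a double-bonded chain carbon bound to a double-bonded chain carbon can be exchanged with a clear loss in this assay: 3,4-dichlorophenyl in place of 4-(methylsulfanyl)phenyl gives a 6.7-fold higher number from compound 2 to compound 3 (0.82 log units; beyond the scatter) and thus carries the numbers further up than the earlier exchange of small substituents had. Set against 4-ethylphenyl, the same group gives a 43-fold higher number from compound 1 to compound 3 (1.63 log units; beyond the scatter), a large step that widens the span at this position well beyond what the first two compounds showed. The three aryl groups now stand in a clear order, with every step among them beyond the scatter and 4-ethylphenyl giving the lowest number, but nothing on hand accounts for that order.

Because 3,4-dichlorophenyl differs from the other two aryl groups in more than one respect, these compounds leave open how much of the loss belongs to either chlorine, and 4-chlorophenyl or 3-chlorophenyl would separate the two. Also open, from the compounds shown here alone, is whether a longer chain such as 4-propylphenyl, or an amine or a carboxylic acid on the ring, would fall below or above the number of compound 1.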